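Inverting every stereocentre of compound 2: an expectation

The compounds below may be only part of what the source reports. "The series", "measured", "known", "first", "only" and "open" are said of these compounds alone.

Measured compounds:
compound 1 `O=C(O)[C@H]1NC[C@H](O)[C@H](O)[C@@H]1O`: 26%
compound 2 `O=C(O)[C@H]1NC[C@@H](O)[C@H](O)[C@@H]1O`: 42%

In an assay on isolated protein for inhibition of cytosolic endo-beta-N-acetylglucosaminidase (Homo sapiens), tested at 1000 uM (a lower number here means less inhibition, a higher number more inhibition at the concentration tested (going by the name of the read-out)), compound 1 gives 26%, and compound 2 gives 42%. Among the measured compounds shown here, compound 2 thus stands highest of the two numbers, with compound 1 as its only neighbour. For the measured compounds named here, the one measured step, a number 16 percentage points higher from compound 1 to compound 2 (beyond the scatter), goes with the fact that compounds 1 and 2 differ only in the configuration as drawn.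

Compound 3 `O=C(O)[C@@H]1NC[C@H](O)[C@@H](O)[C@H]1O` has not yet been measured in this assay. It differs from compound 2 as follows: the two compounds have the same atoms and bonds and differ only in configuration as drawn: 4 of 4 stereo elements differ (all stereocentres are inverted: mirror images); a stereocentre at a saturated ring carbon is drawn S in compound 2 and R in compound 3; a stereocentre at a saturated ring carbon is drawn R in compound 2 and S in compound 3; a stereocentre at a saturated ring carbon is drawn S in compound 2 and R in compound 3; a stereocentre at a saturated ring carbon is drawn R in compound 2 and S in compound 3. The measured step turned a single stereocentre and moved the number modestly. Going by the values given here, the change to compound 3 turns all four at once, giving the mirror image, and no measured step covers such a change; the one step available only shows that a change in configuration alone can shift the number beyond the scatter. An estimated step of a number 22 percentage points lower from compound 2 to compound 3 (beyond the scatter) is therefore expected, with wide uncertainty. For compound 3 an inhibition of about 20% is estimated, in the range 2% to 45%.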

Compound 3, a percentage reported as inhibition, at one concentration (the size of the read-out at that concentration, not a potency): 42%
Beside the measured number, compound 3's estimate is 22 percentage points below it; measured number inside the range.
By their numbers in this assay, from the lowest: compound 1; then compounds 2 and 3 (each within the scatter of the next).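

In this assay, inverting all four stereocentres at once gives no change at the digits printed from compound 2 to compound 3 (within the scatter), so at this single concentration the read-out does not separate this pair of mirror images. Inverting three stereocentres gives a number 16 percentage points higher from compound 1 to compound 3 (beyond the scatter), a step of the same size as the earlier single inversion, so among these compounds the number of inverted centres does not set the size of the step. Any difference among these numbers can lie only in the drawn configuration, because nothing else changes: the fact that compounds 1 and 3 differ only in the configuration as drawn

As far as these compounds go, a single concentration gives no potency, so it remains open whether compound 2 and compound 3 would also match at other concentrations. Also open, from the compounds shown here alone, is how the number would respond if a methyl ester or an amide took the place of the carboxylic acid on the shared core.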